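Swapping an Amide Arm for a Chlorophenyl Arm

This account rests on a few compounds, and the source may have more. Where it says the series, first, only, none or still open, it means among the compounds named here.

Compound 1, `COC(=O)/C=C/c1cccc(N(Cc2ccc(-c3ccc(C(C)(C)C)cc3)cc2)C(=O)C2CCCCC2)c1`: 132 nM
Compound 2, `COC(=O)/C=C/c1cccc(N(Cc2ccc(/C=C/C(=O)NC(C)(C)C)cc2)C(=O)C2CCCCC2)c1`: > 1000 nM

Of the compounds shown here, two with a shared core have been measured so far. In an assay on isolated protein with Bile acid receptor (Homo sapiens) as the target (on this read-out lower numbers stand for an effect already at smaller amounts and higher numbers for an effect only at larger amounts of compound), compound 1 gives 132 nM. Compound 2 is a different case: in this assay compound 2 gives > 1000 nM, which is a limit of the assay rather than a number (the limit of > 1000 nM in this assay, at which 1 of the 2 values shown sits). So compound 2 stands at the weak end of what has been seen, with its true value unknown beyond that limit. Going by the values given here, the one measured step is an at least 7.5-fold higher number from compound 1 to compound 2 (0.87 log units; beyond the scatter), in which an aromatic ring gave way to an amide-bearing chain.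

Compound 3, `COC(=O)/C=C/c1cccc(N(Cc2ccc(/C=C/c3cccc(Cl)c3)cc2)C(=O)C2CCCCC2)c1`, has not yet been measured. It differs from compound 2 in one place: 3-chlorophenyl in place of (tert-butyl)carbamoyl on a double-bonded chain carbon bound to a double-bonded chain carbon. Among the compounds with values here, this change runs the measured step partly backwards, putting an aromatic ring back at the end of the chain, so the step from compound 1 to compound 2 is the only guide. On that basis a drop in the number is expected, and the expected step is an at least 3.3-fold lower number from compound 2 to compound 3 (0.52 log units; beyond the scatter). Compound 3 is estimated to give 300 nM, within a range from 80 nM to 1500 nM.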

Compound 3, half-maximal effective concentration: 165 nM
For compound 3 the middle estimate is 1.8-fold (0.26 log units) above the measured one; the range from low to high includes it.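

In this assay, putting 3-chlorophenyl in place of (tert-butyl)carbamoyl on the chain gives an at least 6.0-fold lower number from compound 2 to compound 3 (0.78 log units; beyond the scatter), so the ethenyl chain by itself does not account for the weak result of compound 2; the loss goes with the amide end of that chain. Compound 2 carries a limit and not a number, so this step gives only a minimum size: the limit of > 1000 nM in this assay, at which 1 of the 3 values shown sits. Putting 2-(3-chlorophenyl)ethenyl in place of 4-(tert-butyl)phenyl gives a 1.3-fold higher number from compound 1 to compound 3 (0.10 log units; within the scatter), which shows that two arms of different shape and length can give results that cannot be told apart, as long as each ends in an aromatic ring.

As far as these compounds go, what remains open is whether the chlorine matters or the aromatic ring alone is enough, a question that a plain phenyl ring at the end of the same chain would answer. It is also unclear how much the chain end accepts beyond carbon rings, for instance a pyridine ring, whose ring nitrogen would test this directly.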